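Trimming a cinnamate ester to a plain acetate

The source may hold more compounds than are shown below. What is called first, only, known or untested is meant among the compounds shown, and "the series" means these compounds.

Compound 1 `O=C1C=C[C@@H](OCc2ccccc2)[C@@H]([C@@H](COC(=O)/C=C/c2ccccc2)OCc2ccccc2)O1`: in a functional assay on MCF7 cells (Homo sapiens) for antiproliferative activity, read by MTT assay, with a stated time of 6 days (a higher number here means a weaker inhibitor, a lower number a stronger inhibitor), compound 1 gives 2570 nM.
Compound 2 `COc1ccc(/C=C/C(=O)OC[C@@H](OCc2ccccc2)[C@H]2OC(=O)C=C[C@H]2OCc2ccccc2)cc1`: in this assay compound 2 gives 1110 nM.
Compound 3 `O=C1C=C[C@@H](OC(=O)c2ccccc2)[C@@H]([C@@H](COC(=O)c2ccccc2)OC(=O)c2ccccc2)O1`: in this assay compound 3 gives 2360 nM.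

Compound 2 holds the lowest number of the three, and its steps to both compound 1 and compound 3 lie beyond the scatter. For the measured compounds named here, the only single-point step among the measured compounds is a 2.3-fold lower number from compound 1 to compound 2 (0.36 log units; beyond the scatter), a modest gain from one added methoxy group.

Compound 4 `CC(=O)OC[C@@H](OCc1ccccc1)[C@H]1OC(=O)C=C[C@H]1OCc1ccccc1` differs from compound 2 in one place: methyl in place of 2-(4-methoxyphenyl)ethenyl on a carbonyl carbon. This removes far more than the methoxy group whose addition produced a 2.3-fold lower number from compound 1 to compound 2 (0.36 log units; beyond the scatter); the whole aryl-ethenyl piece goes, leaving an acetate. Going by the values given here, no measured step covers that exact cut. Compound 3, which carries no such ethenyl-aryl piece, sits near compound 1 in value, which hints that losing it costs roughly what the methoxy gained, or somewhat more. Compound 4 is therefore expected to give a higher number than compound 2, with an estimated step of a 2.5-fold higher number from compound 2 to compound 4 (0.40 log units; beyond the scatter). The estimate for compound 4 in this assay is 2800 nM, within a range from 1000 nM to 8000 nM.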

Compound 4, half-maximal inhibitory concentration: 18900 nM
Estimate against measurement, compound 4: 6.8-fold (0.83 log units) below; measured number above the stated range.
By their numbers in this assay, from the lowest: compound 2; then compounds 3 and 1 (each within the scatter of the next); then compound 4.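

In this assay, replacing 2-(4-methoxyphenyl)ethenyl with methyl on the carbonyl carbon gives a 17-fold higher number from compound 2 to compound 4 (1.23 log units; beyond the scatter), and replacing 2-phenylethenyl with methyl gives a 7.4-fold higher number from compound 1 to compound 4 (0.87 log units; beyond the scatter). Both steps are larger than the methoxy step, a 2.3-fold lower number from compound 1 to compound 2 (0.36 log units; beyond the scatter), so at this position the aryl-ethenyl piece as a whole counts for much more than the methoxy group it can carry. Nothing available explains why the acetate loses so much.

On these data alone, the double bond and the aromatic ring leave together in these changes, so their separate shares remain unknown. A 2-phenylethyl group on the same carbonyl carbon would keep the ring without the double bond, while a plain hexyl chain would have neither, and either could help tell the two apart.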